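A few compounds are considered here, and "the series" means these few. Any claim that something is new, unique, unknown or untested is made for them only; others in the source may bear on it.

Among the measured compounds shown here, compound 1 `COc1cccc(C(=O)NNC(=O)c2ccc3[nH]c(-c4ccc([N+](=O)[O-])o4)nc3c2)c1` carries a 3-methoxyphenyl group on the shared core, and in a functional assay on DU-145 cells (Homo sapiens) for inhibition, read by sulforhodamine B assay, with a stated time of 48 h (a higher number here means a weaker inhibitor of growth, a lower number a stronger inhibitor of growth), compound 1 gives 15.6 ug/mL, the only plain number so far. Compound 2 `O=C(NNC(=O)c1ccc2[nH]c(-c3ccc([N+](=O)[O-])o3)nc2c1)c1cccc(Oc2ccccc2)c1` gives > 7.8 ug/mL, which is a limit and not a number. For the measured compounds named here, the only measured step is a step that the limit leaves unreadable from compound 1 to compound 2, where phenyl takes the place of methyl on an oxygen on an aromatic ring, so it offers no size to carry over. Compound 3 `COc1ccc(C(=O)NNC(=O)c2ccc3[nH]c(-c4ccc([N+](=O)[O-])o4)nc3c2)cc1OC` differs from compound 1 in one place, 3-methoxyphenyl to 3,4-dimethoxyphenyl: methoxy in place of hydrogen on an aromatic carbon. With no readable step to draw on, no change beyond the usual scatter is expected in this assay, in either direction. The expected step is a 1.0-fold lower number from compound 1 to compound 3 (0.02 log units; within the scatter). For compound 3 the estimate is 15 ug/mL, with an expected range of 5 ug/mL to 45 ug/mL.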

Compound 3, concentration for 50% growth inhibition: 15.6 ug/mL
Compound 3: middle estimate off by 1.0-fold (0.02 log units), on the low side; low and high end bracket the measured number.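

Methoxy in place of hydrogen on an aromatic carbon, ortho to a methoxy group and para to a large group, gives the first readable step in this assay, with no change at the digits printed from compound 1 to compound 3 (within the scatter) as its result. Among the compounds shown here, this shows what the earlier compounds could not: at this position, a second methoxy leaves the growth-inhibition reading where it stood. The step to compound 2 cannot be read, as compound 2 is recorded only as a limit: the limit of > 7.8 ug/mL in this assay, at which 1 of the 3 values shown sits.

The compounds shown leave open whether a group other than methoxy at this position, such as an amine or a carboxylic acid, would move the reading beyond the scatter. They also leave open what a longer chain on the oxygen, such as ethoxy or propoxy, would do.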